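Second phenyl on the ether carbon: compound 4

A few compounds are considered here, and "the series" means these few. Any claim that something is new, unique, unknown or untested is made for them only; others in the source may bear on it.

Compound 1 `N[C@]1(C(=O)O)[C@H]2[C@@H](C[C@H]1OCc1ccccc1)[C@]2(F)C(=O)O` stands second highest of the three numbers in an assay on CHO cells for binding affinity to metabotropic glutamate receptor 2 (Rattus norvegicus) (a higher number here means a weaker inhibitor, a lower number a stronger inhibitor), giving 7.14 nM. Compound 2 `N[C@]1(C(=O)O)[C@H]2[C@@H](C[C@H]1OCCCc1ccccc1)[C@]2(F)C(=O)O` gives 9.83 nM and compound 3 `N[C@]1(C(=O)O)[C@H]2[C@@H](C[C@H]1OCc1cccc(F)c1F)[C@]2(F)C(=O)O` gives 4.25 nM; the steps of a 1.4-fold higher number from compound 1 to compound 2 (0.14 log units; within the scatter) and a 1.7-fold lower number from compound 1 to compound 3 (0.23 log units; within the scatter) both stay within the scatter, while a 2.3-fold lower number from compound 2 to compound 3 (0.36 log units; beyond the scatter) is modest. Compound 4 `N[C@]1(C(=O)O)[C@H]2[C@@H](C[C@H]1OC(c1ccccc1)c1ccccc1)[C@]2(F)C(=O)O` differs from compound 1 by phenyl in place of hydrogen on a saturated chain carbon bound to an aromatic carbon and an oxygen on a saturated carbon. Among the compounds with values here, no measured step adds a second aromatic group at this carbon; the nearest comparisons, a 1.4-fold higher number from compound 1 to compound 2 (0.14 log units; within the scatter) and a 1.7-fold lower number from compound 1 to compound 3 (0.23 log units; within the scatter), show that changes at the ether substituent have so far moved this assay little. A step of a 1.7-fold higher number from compound 1 to compound 4 (0.23 log units; within the scatter) is therefore expected, hardly beyond the scatter. Compound 4 is estimated at 12 nM, ranging from 5 nM to 35 nM.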

Compound 4, inhibition constant: 2.58 nM
The estimate for compound 4 lay 4.7-fold (0.67 log units) above the measured number, outside the stated range (below it).
By their numbers in this assay, from the lowest: compounds 4, 3, 1 and 2 (each within the scatter of the next, the first and the last beyond it).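

In this assay, within the data shown here, phenyl in place of hydrogen on the saturated chain carbon bound to an aromatic carbon and an oxygen on a saturated carbon gives a 2.8-fold lower number from compound 1 to compound 4 (0.44 log units; beyond the scatter) and is the only step from compound 1 at this ether substituent that lies beyond the scatter. This carbon therefore takes a second phenyl without loss of binding. Nothing available explains the gain.

Open, from the compounds shown here alone, is whether a smaller group at this carbon, such as methyl, would give a similar step. Also open, going by these compounds, is whether a carboxylic acid or an amine on the added phenyl would keep it.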